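From cyclopentyl to 4,4-difluorocyclohexyl on a shared core

The compounds below may be only part of what the source reports. "The series", "measured", "known", "first", "only" and "open" are said of these compounds alone.

Three related compounds have been tested in a physicochemical assay for solubility, using the shake flask method, measured as kinetic solubility, with a stated time of 20 h, at pH 2; on this read-out higher numbers stand for higher solubility and lower numbers for lower solubility. Compound 1 `Fc1cnc(Nc2cc3[nH]c(-c4cccc(C(F)(F)F)c4)nc3cn2)c(F)c1` gives < 5000 nM, which is a limit of the assay and not a number. Compound 2 `Fc1ccc(Nc2cc3[nH]c(-c4ccc(F)c(F)c4)nc3cn2)nc1` reads 42000 nM. Compound 3 `FC(F)(F)c1ccc(Nc2cc3[nH]c(C4CCCC4)nc3cn2)nc1` reads 132000 nM, the higher of the two actual numbers and beyond the scatter from compound 2.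

Compound 4 `FC1(F)CCC(c2nc3cnc(Nc4ccc(C(F)(F)F)cn4)cc3[nH]2)CC1` has not yet been measured. It carries 4,4-difluorocyclohexyl in place of cyclopentyl on an aromatic carbon. Within the data shown here, no measured pair differs in just one place, so the size of this change remains a judgement. The expected change is a moderate fall beyond the scatter, a 3.3-fold lower number from compound 3 to compound 4 (0.52 log units; beyond the scatter). Compound 4 is estimated at 40000 nM, with an expected range of 10000 nM to 120000 nM.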

Compound 4, solubility: 199000 nM
Compound 4: the middle estimate sits 5.0-fold (0.70 log units) below what was measured, and the stated range ends below it.
By their numbers in this assay, from the lowest: compound 2; then compounds 3 and 4 (each within the scatter of the next). At a limit, below all of these: compound 1.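

In this assay, putting 4,4-difluorocyclohexyl in place of cyclopentyl gives a 1.5-fold higher number from compound 3 to compound 4 (0.18 log units; within the scatter). Among these compounds, this is the first comparison here that differs in one place, and it shows that compound 3 and compound 4 read alike with either ring on this aromatic carbon between two ring nitrogen atoms. No measurement at hand bears on why the two rings read alike.

From the compounds shown here alone, only these two non-aromatic carbon rings can be compared at this position, so the reading with an amine or a carboxylic acid there remains open. Going by these compounds, whether the same exchange holds with other groups elsewhere on the shared core also remains open.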